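Adding a Methyl Group to Compound 2

The source may hold more compounds than are shown below. What is called first, only, known or untested is meant among the compounds shown, and "the series" means these compounds.

For the measured compounds named here, in a functional assay on RKO cells (Homo sapiens) for cytotoxicity, read by resazurin assay, with a stated time of 72 h (a higher number here means a weaker inhibitor, a lower number a stronger inhibitor), compound 2 `Cc1nccn1-c1csc(Nc2ccccc2)n1` gives 32500 nM, the higher of the two numbers measured so far. Compound 1 `COc1ccc(Nc2nc(-n3ccnc3C)cs2)cc1` gives 1600 nM. Compound 3 `Cc1ccc(Nc2nc(-n3ccnc3C)cs2)cc1` alters compound 2 by methyl in place of hydrogen on an aromatic carbon, para to a large group. Going by the values given here, one measured step bears on this change, the swap of methoxy for hydrogen on that same carbon, which gave a 20-fold higher number from compound 1 to compound 2 (1.31 log units; beyond the scatter). That large step suggests that a group at this carbon can lower the number, but no methyl case has been measured, so only part of that step is expected to return. The expected change is a 5.4-fold lower number from compound 2 to compound 3 (0.73 log units; beyond the scatter), a step beyond the scatter toward a lower number. For compound 3 the estimated value is 6000 nM, with an expected range of 1800 nM to 20000 nM.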

Compound 3, half-maximal inhibitory concentration: 450 nM
Beside the measured number, compound 3's estimate is 13-fold (1.12 log units) above it; the measured number lies below the stated range.
By their numbers in this assay, from the lowest: compound 3; then compound 1; then compound 2.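

In this assay, a single methyl group on this aromatic carbon, para to a large group, is enough for a large gain, with a 72-fold lower number from compound 2 to compound 3 (1.86 log units; beyond the scatter) in the number. The oxygen of methoxy is therefore not required for a low number here, and replacing methoxy with methyl goes further still, with a 3.6-fold lower number from compound 1 to compound 3 (0.55 log units; beyond the scatter) in a modest step beyond the scatter. No measurement on hand accounts for either step.

The compounds shown cannot say whether ethyl, a chlorine atom or an amine on this same carbon would lower the number further or raise it again. They also leave open whether methyl on another carbon of this six-membered ring would give a step of similar size.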